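Hydroxy in Place of Fluoro: Expected Cytotoxicity of Compound 4

The compounds below may be only part of what the source reports. "The series", "measured", "known", "first", "only" and "open" are said of these compounds alone.

The study examined three measured compounds and one still to be measured in an ADME assay on BHK cells (Mesocricetus auratus) for cytotoxicity, read by MTT assay, with a stated time of 96 h; on this read-out lower numbers stand for higher toxicity in this test and higher numbers for lower toxicity in this test. Compound 1 `Fc1ccc(-c2nc3cc(C(F)(F)F)ccc3[nH]2)cc1` is the only one of the three that returns a number: in this assay compound 1 gives 25000 nM. Compound 2 `COc1ccc(-c2nc3cc(Cl)c(Cl)cc3[nH]2)c(N)c1` reaches only a limit of the assay, > 100000 nM in this assay. Compound 3 `CC(=O)Nc1ccc(-c2nc3cc(C(F)(F)F)ccc3n2C)cc1` likewise reaches only a limit, > 100000 nM in this assay. Compound 1 therefore stands alone as a measured value, while the other two sit at the boundary described by the limit of > 100000 nM in this assay, at which 2 of the 3 values shown sit. Among the measured compounds shown here, no pair of these measured compounds differs in only one place, so no single step can be read from them.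

Compound 4 `Oc1ccc(-c2nc3cc(C(F)(F)F)ccc3[nH]2)cc1` is derived from compound 1 by one change: hydroxy in place of fluoro on an aromatic carbon. The hydroxy enters on the aromatic carbon of the six-membered carbon-only ring, para to a large group, where the fluoro stood. With compound 1 at 25000 nM as the only reference, the step of a 1.4-fold higher number from compound 1 to compound 4 (0.15 log units; within the scatter) in this assay is expected to be small, not beyond the usual scatter, with at most a slight lean toward lower toxicity. Compound 4 is accordingly estimated at 35000 nM in this assay, within a range from 12000 nM to 100000 nM.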

Compound 4, half-maximal cytotoxic concentration: > 100000 nM
Compound 4: a limit, no number; the forecaster's own chance of this, stated with the estimate: 30%; middle value at least 2.8-fold (0.45 log units) away from the limit.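

Hydroxy in place of fluoro on an aromatic carbon, para to a large group, gives an at least 4.0-fold higher number from compound 1 to compound 4 (0.60 log units; beyond the scatter) in this assay and is the only single change here that can be read, lying beyond the scatter and toward lower toxicity in this test. Compound 4 gives > 100000 nM as a limit of the assay and not a number, so the step marks how far the read-out moved at the least and does not give its full size. This place on compound 1 is thus shown to respond to the exchange of one heavy atom, yet compound 4 adds no second number to the series and joins the others at the limit: the limit of > 100000 nM in this assay, at which 3 of the 4 values shown sit.

How far hydroxy moves the read-out past that limit stays open, as does the question of whether the change would do the same on the other compounds shown. From the compounds shown here alone, it also remains open how a carboxylic acid or a nitrile at this same place would compare with fluoro and hydroxy.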